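From (isobutylcarbonyl)oxy to cyano on a shared core

The source may report more compounds than this note shows. Statements on the series, on what has been measured and on what is new or still open speak of the compounds shown alone.

Measured so far in a functional assay on DLD-1 cells (Homo sapiens) for cytotoxicity, with a stated time of 48 h; a lower number here means a stronger inhibitor, a higher number a weaker inhibitor:
- compound 1 `CC(C)CC(=O)Oc1ccc2oc(/C=C/[S+](C)[O-])cc(=O)c2c1`: 6100 nM
- compound 2 `Cc1cccc2oc(/C=C/[S+](C)[O-])cc(=O)c12`: 5500 nM

Among the measured compounds shown here, only two compounds have numbers so far. Compound 1 at 6100 nM and compound 2 at 5500 nM lie within the usual scatter of repeated measurements, so the two cannot be told apart. For the measured compounds named here, compound 1 therefore stands level with the only other measured compound.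

The next compound is compound 3 `C[S+]([O-])/C=C/c1cc(=O)c2cc(C#N)ccc2o1`. It keeps the core of compound 1 but has cyano in place of (isobutylcarbonyl)oxy on an aromatic carbon. Going by the values given here, no measured pair shows what this exchange does in this assay, so any forecast rests on thin evidence. Among the compounds with values here, the one hint is that compound 2, which carries a different group on the shared core, gives 5500 nM, within the scatter of compound 1. On that basis, no change beyond the scatter is expected in either direction, though a larger one cannot be ruled out. The expected step of a 1.0-fold lower number from compound 1 to compound 3 (0.01 log units; within the scatter) is only an estimate. For compound 3 the estimated value is 6000 nM, with an expected range of 2000 nM to 18000 nM.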

Compound 3, half-maximal inhibitory concentration: > 10000 nM
Compound 3 ended at the assay's limit; the forecaster's own chance of this, stated with the estimate: 10%; middle value at least 1.6-fold (0.22 log units) away from the limit.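

In this assay compound 3 gives > 10000 nM, which is a limit of the assay and not a measured number. Placing cyano where (isobutylcarbonyl)oxy stood, on the aromatic carbon meta to a fused ring and para to a fused ring, gives an at least 1.6-fold higher number from compound 1 to compound 3 (0.21 log units; that floor lies within the scatter), so this exchange brings no sign of a stronger inhibitor, but the floor of the step does not by itself establish a real weakening. The earlier compounds offered no matched pair at this position, and this first one fixes only a lower edge for the step, not its size, with compound 3 alone at the assay's ceiling so far: the limit of > 10000 nM in this assay, at which 1 of the 3 values shown sits.

On these data alone, it remains open whether the true value of compound 3 lies just past the limit or far beyond it, and therefore whether this exchange matters much or little. As far as these compounds go, it is also open how an amine, a carboxylic acid or a hydroxyl group on the same aromatic carbon would compare with (isobutylcarbonyl)oxy and cyano on the shared core.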